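A Smaller Halogenated Aryl Group on the Shared Core

The source may hold more compounds than are shown below. What is called first, only, known or untested is meant among the compounds shown, and "the series" means these compounds.

Three compounds sharing one core were tested in a functional assay on PC-3 cells (Homo sapiens) for inhibition, read by MTT assay, with a stated time of 72 h, tested at 10 uM; on this read-out lower numbers stand for less inhibition of growth and higher numbers for more inhibition of growth at the one concentration tested. Compound 1 `COc1cc2ncnc(Nc3ccc([N+](=O)[O-])cc3)c2c(OC)c1OC` gives 24.9%, and compound 2 `COc1cc2ncnc(Nc3cc(C(F)(F)F)ccc3Br)c2c(OC)c1OC` gives 25.3%. Compound 3 `COc1cc2ncnc(Nc3ccc(Br)cc3Cl)c2c(OC)c1OC` gives 49.7%, the highest of the three numbers; its distance to compound 2 is beyond the scatter, as is its distance to compound 1, so compound 3 is the strongest inhibitor of growth among the measured set.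

Compound 4 `COc1cc2ncnc(Nc3ccccc3F)c2c(OC)c1OC` has not yet been measured in this assay. It differs from compound 3 in one place: 2-fluorophenyl in place of 4-bromo-2-chlorophenyl on a nitrogen on an aromatic ring. The 2-fluorophenyl group enters on a nitrogen on an aromatic ring whose other neighbour is aromatic carbon.

Among the measured compounds shown here, no measured pair shows this change, so the expectation rests on the spread of the three numbers. Since compound 1 gives 24.9% and compound 2 gives 25.3% with other aryl groups, the estimate is a downward step a number 24.7 percentage points lower from compound 3 to compound 4 (beyond the scatter) from compound 3 to compound 4, beyond the scatter. Compound 4 is expected to give 25%, within a range from 8% to 45%.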

Compound 4, percent growth inhibition at one concentration: 24%
Beside the measured number, compound 4's estimate is 1 percentage points above it; the range from low to high includes it.
By their numbers in this assay, from the lowest: compounds 4, 1 and 2 (each within the scatter of the next); then compound 3.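

In this assay, among the compounds shown here, exchanging 4-bromo-2-chlorophenyl for 2-fluorophenyl on the nitrogen gives a number 25.7 percentage points lower from compound 3 to compound 4 (beyond the scatter), the first step in this set in which only one place changes. For the compounds shown here, with the shared core held constant, it shows that inhibition of growth at the one concentration tested depends on which aryl group sits at this place, something the earlier compounds could not isolate because no two of them formed such a pair. No measurement shown here accounts for the size of this step.

As far as these compounds go, the change removes bromine and chlorine and brings in fluorine all at once, so the contribution of each halogen remains open. Also open, from the compounds shown here alone, is how an aryl group carrying an amine or a carboxylic acid would behave at this place.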